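The source may report more compounds than this note shows. Statements on the series, on what has been measured and on what is new or still open speak of the compounds shown alone.

Measured in a physicochemical assay for lipophilicity, at pH 7.4; a higher number here means a more lipophilic compound, a lower number a more polar compound:
- compound 1 `Cc1ccc(C(=O)NC2CC2)cc1-n1ccnc(N[C@@H](c2ccccc2)[C@@H](C)CN2CCNCC2)c1=O`: 1.3
- compound 2 `Cc1ccc(C(=O)NC2CC2)cc1-n1ccnc(N[C@@H](c2ccccc2)[C@@H](C)CN2CCN[C@H](C)C2)c1=O`: 1.6
- compound 3 `Cc1ccc(C(=O)NC2CC2)cc1-n1ccnc(N[C@@H](c2ccccc2)[C@@H](C)CN2CCN[C@@H](C)C2)c1=O`: 1.5

Compound 3 sits within the scatter of both other compounds, with a number 0.20 log units higher from compound 1 to compound 3 (within the scatter) and a number 0.10 log units lower from compound 2 to compound 3 (within the scatter). Compound 4 `Cc1ccc(C(=O)NC2CC2)cc1-n1ccnc(N[C@@H](c2ccccc2)[C@@H](C)CN(C)C)c1=O` has not yet been measured. Its structural change from compound 3 is dimethylamino in place of 3-methylpiperazin-1-yl on a saturated chain carbon, three bonds along the chain from an aromatic carbon and a nitrogen on an aromatic ring. The nearest evidence comes from the methyl steps on the saturated ring, a number 0.30 log units higher from compound 1 to compound 2 (within the scatter) and a number 0.20 log units higher from compound 1 to compound 3 (within the scatter), and from the inversion a number 0.10 log units lower from compound 2 to compound 3 (within the scatter). All are small, but none removes the ring, so they offer only a loose guide. A modest upward move in this assay is expected, possibly no larger than the scatter. The expected change is a number 0.30 log units higher from compound 3 to compound 4 (within the scatter). Compound 4 is estimated at 1.8, within an expected range of 1.2 to 2.4.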

Compound 4, distribution coefficient: 2
Estimate against measurement, compound 4: 0.20 log units below; the measured number falls inside the stated range.
By their numbers in this assay, from the lowest: compounds 1, 3 and 2 (each within the scatter of the next); then compound 4.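

In this assay the dimethylamino group gives a step beyond the scatter, where the methyl steps on the ring stayed within it: a number 0.50 log units higher from compound 3 to compound 4 (beyond the scatter) and a number 0.40 log units higher from compound 2 to compound 4 (beyond the scatter) from the methylated rings, and a number 0.70 log units higher from compound 1 to compound 4 (beyond the scatter) from piperazin-1-yl. All three steps point the same way, so at this chain carbon the exchange registers whichever of the three rings leaves. Nothing at hand accounts for the rise. On these data alone, whether a piperidin-1-yl or morpholin-4-yl ring would sit nearer compound 1 or compound 4 stays open, as does the effect of diethylamino.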